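Swapping the aromatic ring for a small amine side chain

A few compounds are considered here, and "the series" means these few. Any claim that something is new, unique, unknown or untested is made for them only; others in the source may bear on it.

Compound 1 `CC(C)(C)C(=O)N1Cc2c(NC(=O)c3cccnc3)n[nH]c2C1(C)C`: 690 nM
Compound 2 `CN1CCC(C(=O)N2Cc3c(NC(=O)c4cc(F)cc(F)c4)n[nH]c3C2(C)C)CC1`: 130 nM

In a functional assay on A2780 cells (Homo sapiens) for antiproliferative activity, read by fluorescence, with a stated time of 72 h (a higher number here means a weaker inhibitor, a lower number a stronger inhibitor), compound 1 gives 690 nM, the higher of the two numbers and so the weaker result. Compound 2 gives 130 nM, a gap beyond the usual scatter. These two compounds differ in more than one place, so their gap cannot be pinned on any single change.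

Compound 3 `CN(C)CC(=O)Nc1n[nH]c2c1CN(C(=O)C(C)(C)C)C2(C)C` keeps the core of compound 1 and changes one group: (dimethylamino)methyl in place of pyridin-3-yl on a carbonyl carbon. In words, (dimethylamino)methyl stands in place of pyridin-3-yl on a carbonyl carbon. Going by the values given here, no measured pair shows this change alone, so the forecast is uncertain. Compound 1 and compound 2 both carry an aromatic ring there, while compound 3 has none. A weakening beyond the scatter is expected, with the estimated step of a 4.3-fold higher number from compound 1 to compound 3 (0.64 log units; beyond the scatter). Compound 3 is estimated at 3000 nM, with an expected range of 700 nM to 12000 nM.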

Compound 3, half-maximal inhibitory concentration: 580 nM
The estimate for compound 3 lay 5.2-fold (0.71 log units) above the measured number, and the stated range ends above it.
By their numbers in this assay, from the lowest: compound 2; then compounds 3 and 1 (each within the scatter of the next).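

In this assay, placing (dimethylamino)methyl in place of pyridin-3-yl on a carbonyl carbon gives a 1.2-fold lower number from compound 1 to compound 3 (0.08 log units; within the scatter), so the two groups cannot be told apart here. Compound 1 and compound 2 both carry an aromatic ring at this place and so could not show whether a ring is needed there; compound 3 shows that, on this core, a side chain with no ring reads the same as pyridin-3-yl. Nothing measured here explains why the two groups read alike.

Still open, from the compounds shown here alone, is whether a longer chain ending in the same dimethylamino group, a morpholine ring or a carboxylic acid on this carbonyl carbon would also read the same. Going by these compounds, it is also open whether the same swap would leave the number unchanged with the rest of compound 2 in place of the rest of compound 1.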